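Reversed amide side chain: compound 3 to compound 4

The source may report more compounds than this note shows. Statements on the series, on what has been measured and on what is new or still open speak of the compounds shown alone.

Measured compounds:
Compound 1, `CCOC(=O)CN1CCC(CCCn2c(COc3ccc(Cl)cc3)nc3c(C)cccc32)CC1`, in an assay on AV12 cells for binding affinity to Neuropeptide Y receptor type 1 (Homo sapiens) (on this read-out lower numbers stand for stronger inhibition and higher numbers for weaker inhibition), gives 427 nM
Compound 2, `Cc1cccc2c1nc(COc1ccc(Cl)cc1)n2CCCC1CCN(CC(=O)O)CC1`, in this assay gives 2190 nM
Compound 3, `Cc1cccc2c1nc(COc1ccc(Cl)cc1)n2CCCC1CCN(CCCC(=O)N2CCCCC2)CC1`, in this assay gives 21 nM

Compound 3 holds the lowest of the three numbers in this assay; the steps of a 20-fold lower number from compound 1 to compound 3 (1.31 log units; beyond the scatter) and a 100-fold lower number from compound 2 to compound 3 (2.02 log units; beyond the scatter) are both large and beyond the scatter, and a 5.1-fold higher number from compound 1 to compound 2 (0.71 log units; beyond the scatter) is modest.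

Compound 4, `Cc1cccc2c1nc(COc1ccc(Cl)cc1)n2CCCC1CCN(C(=O)CCN2CCCCC2)CC1`, differs from compound 3 in one place: (2-(piperidin-1-yl)ethyl)carbonyl in place of 3-((piperidin-1-yl)carbonyl)propyl on an amine nitrogen in a ring. The piperidine and the carbonyl are kept, but the chain is turned round so that the carbonyl sits directly on the ring nitrogen. Among the measured compounds shown here, no measured step shows such a reversal. For the measured compounds named here, the steps that bear on it only loosely are a 20-fold lower number from compound 1 to compound 3 (1.31 log units; beyond the scatter) and a 100-fold lower number from compound 2 to compound 3 (2.02 log units; beyond the scatter), which show that this assay answers strongly to what stands on this ring nitrogen, yet in all three measured compounds that nitrogen remains an amine, whereas in compound 4 it does not. The direction is therefore uncertain; a loss of part of the gain seen in compound 3 is the more cautious reading.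

Compound 4 is expected to give about 65 nM in this assay, within 15 nM to 300 nM. The estimated step is a 3.1-fold higher number from compound 3 to compound 4 (0.49 log units; beyond the scatter), modest and beyond the scatter.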

Compound 4, inhibition constant: 260 nM
Beside the measured number, compound 4's estimate is 4.0-fold (0.60 log units) below it; the range from low to high includes it.
By their numbers in this assay, from the lowest: compound 3; then compounds 4 and 1 (each within the scatter of the next); then compound 2.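

In this assay, keeping the piperidine and the carbonyl is not enough to hold the number: turning the chain round, so that (2-(piperidin-1-yl)ethyl)carbonyl stands on the ring nitrogen, gives a 12-fold higher number from compound 3 to compound 4 (1.09 log units; beyond the scatter), and so this position answers to how the chain is arranged and not only to which groups it carries. The reversed chain still keeps a clear lead over the acid, with an 8.4-fold lower number from compound 2 to compound 4 (0.93 log units; beyond the scatter), but a 1.6-fold lower number from compound 1 to compound 4 (0.22 log units; within the scatter) leaves it unseparated from the ethyl ester, so the gain seen with 3-((piperidin-1-yl)carbonyl)propyl is not retained. No independent measurement bears on why the reversal has this effect.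

The step changes two things at once, since the carbonyl moves onto the ring nitrogen and the chain between the ring nitrogen and the terminal piperidine also changes, and the compounds shown do not separate these two changes. As far as these compounds go, a 3-(piperidin-1-yl)propyl group on that nitrogen, which is an amine with no carbonyl, or a longer chain between the carbonyl and the piperidine would help to tell them apart, and a morpholine in place of the terminal piperidine is also open.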